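The source may hold more compounds than are shown below. What is called first, only, known or untested is meant among the compounds shown, and "the series" means these compounds.

Measured compounds in a functional assay on A549 cells (Homo sapiens), read by MTT assay, with a stated time of 72 h; a lower number here means a stronger inhibitor, a higher number a weaker inhibitor:
compound 1 `C#Cc1cn([C@@H]2O[C@H](CO)[C@@H](O)[C@H]2O)c2ncnc(C)c12` gives 19200 nM
compound 2 `COc1ncnc2c1c(-c1cccs1)cn2[C@@H]1O[C@H](CO)[C@@H](O)[C@H]1O` gives 4850 nM

Compound 2 holds the lower of the two numbers in this assay; compound 1 sits a clear step away from it, beyond the scatter. The two measured compounds differ in more than one place, so no single step can be read from them. Compound 3 `C#Cc1cn([C@@H]2O[C@H](CO)[C@@H](O)[C@H]2O)c2ncnc(OC)c12` shares the methoxy of compound 2 and differs from it as follows: ethynyl in place of thiophen-2-yl on an aromatic carbon. Compound 1 carries the same ethynyl group and gives the weaker reading, so compound 3 is expected to lose some ground, with a step of a 2.5-fold higher number from compound 2 to compound 3 (0.39 log units; beyond the scatter) that is estimated to exceed the scatter. Compound 3 is expected at about 12000 nM, within 4000 nM to 40000 nM.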

Compound 3, half-maximal inhibitory concentration: 8160 nM
Estimate against measurement, compound 3: 1.5-fold (0.17 log units) above; low and high end bracket the measured number.
By their numbers in this assay, from the lowest: compounds 2 and 3 (each within the scatter of the next); then compound 1.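

In this assay, ethynyl in place of thiophen-2-yl on this aromatic carbon gives a step within the scatter (a 1.7-fold higher number from compound 2 to compound 3 (0.23 log units; within the scatter)), so with methoxy held fixed the reading does not separate a group with a ring from one without. With ethynyl held fixed, methoxy in place of methyl on an aromatic carbon gives a modest step beyond the scatter (a 2.4-fold lower number from compound 1 to compound 3 (0.37 log units; beyond the scatter)). No available measurement gives a reason for either step. From the compounds shown here alone, it remains open whether an amine or a longer alkyl chain on the ethynyl-bearing carbon would separate from these two groups. Going by these compounds, it also remains open whether the methoxy step holds with thiophen-2-yl on that carbon.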